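The source may hold more compounds than are shown below. What is called first, only, known or untested is meant among the compounds shown, and "the series" means these compounds.

Measured so far in an ADME assay on TZM cells (Homo sapiens) for cytotoxicity, read by CCK-8 assay, with a stated time of 2 days; on this read-out higher numbers stand for lower toxicity in this test and lower numbers for higher toxicity in this test:

Compound 1, `O=C(Nc1ccc(CCS(=O)(=O)/C=C/c2ccc(O)c(O)c2)cc1)c1ccccc1`: 238000 nM
Compound 2, `O=C(Nc1ccc(CCS(=O)(=O)/C=C/c2ccc(O)c(O)c2)cc1)C1CCCCC1`: 638000 nM

Compound 2 stands at the higher of the two numbers, and the step of a 2.7-fold higher number from compound 1 to compound 2 (0.43 log units; beyond the scatter) shows that gap to be beyond the scatter. Compound 3, `O=C(Nc1ccc(CCS(=O)(=O)/C=C/c2ccc(O)c(O)c2)cc1)c1ccc([N+](=O)[O-])cc1`, differs from compound 2 in one place: 4-nitrophenyl in place of cyclohexyl on a carbonyl carbon. For the measured compounds named here, the only measured step that bears on this change is a 2.7-fold higher number from compound 1 to compound 2 (0.43 log units; beyond the scatter), in which an aromatic six-membered ring gave way to a saturated one on the same carbonyl carbon. Compound 3 puts an aromatic ring back in that place, now as 4-nitrophenyl, so a step of similar size in the opposite direction, towards a lower number, is the natural expectation; the effect of the added nitro group itself cannot be read from the two measured compounds. The expected step is therefore a 2.9-fold lower number from compound 2 to compound 3 (0.46 log units; beyond the scatter). Compound 3 is estimated at 220000 nM, with a range from 90000 nM to 550000 nM.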

Compound 3, half-maximal cytotoxic concentration: 483000 nM
Estimate against measurement, compound 3: 2.2-fold (0.34 log units) below, within the range that was stated.
By their numbers in this assay, from the lowest: compound 1; then compounds 3 and 2 (each within the scatter of the next).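

In this assay, 4-nitrophenyl in place of cyclohexyl on the carbonyl carbon gives a 1.3-fold lower number from compound 2 to compound 3 (0.12 log units; within the scatter), so an aromatic ring at this position does not always go with a number clearly apart from that of the saturated ring. Nitro in place of hydrogen on the phenyl ring gives a 2.0-fold higher number from compound 1 to compound 3 (0.31 log units; beyond the scatter), a modest step, which shows that what the aromatic ring carries can change the reading and that the gap between the phenyl and cyclohexyl compounds is not a matter of ring type alone. Nothing measured here explains either step.

Still open, as far as these compounds go, is whether this step belongs to nitro itself, or whether an amine or a carboxylic acid in its place would give a similar number. These compounds also cannot show whether a longer chain between the carbonyl carbon and the ring would change the reading.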